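Working notes on the sulfonamide series, compound 3 to compound 4

The source may hold more compounds than are shown below. What is called first, only, known or untested is meant among the compounds shown, and "the series" means these compounds.

Three compounds have so far been run in an ADME assay (liver) for metabolic stability, with Liver microsome (Homo sapiens) as the target, read by LC-MS, using microsomes and NADPH, with a stated time of 5 min, at 37 degrees C; on this read-out lower numbers stand for slow clearance and higher numbers for fast clearance. Compound 1 `CCn1c([C@@H](C)NS(=O)(=O)c2ccc(Cl)cc2)nc2ccc(OC)cc21` returns only a limit of the assay rather than a number, > 100 mL.min-1.g-1; this reading is the limit of > 100 mL.min-1.g-1 in this assay, at which 1 of the 3 values shown sits. Compound 2 `CCn1c(C(C)NS(=O)(=O)c2ccc(Cl)cc2)nc2cccnc21` gives 94 mL.min-1.g-1 in this assay, sitting close to that fast edge. Compound 3 `CCn1c([C@@H](C)NS(=O)(=O)C2CC2)nc2ccc(C(F)(F)F)cc21` stands at the opposite end: its reading is again a limit of the assay and not a number, < 3 mL.min-1.g-1, which is the limit of < 3 mL.min-1.g-1 in this assay, at which 1 of the 3 values shown sits. No pair among these three differs in a single place, so no measured step can be read from them; the three values simply stand as they are.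

Compound 4 `CCn1c([C@@H](C)NS(=O)(=O)c2ccccn2)nc2ccc(C(F)(F)F)cc21` differs from compound 3 by pyridin-2-yl in place of cyclopropyl on a sulfonyl sulfur. Compound 1 and compound 2, each carrying an aromatic ring on the sulfonyl sulfur, both sit at the fast end, but each also carries a different core, so nothing in the data isolates the sulfonyl substituent as the cause of their readings.

The step from compound 3 to compound 4 is expected to be an increase beyond the usual scatter: an at least 5.0-fold higher number from compound 3 to compound 4 (0.69 log units; beyond the scatter). Compound 4 is estimated at 15 mL.min-1.g-1, with a range from 3 mL.min-1.g-1 to 60 mL.min-1.g-1, and with a real chance that this assay again returns only its lower limit.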

Compound 4, intrinsic clearance in microsomes: < 3 mL.min-1.g-1
Compound 4: only a limit was reported; the forecaster's own chance of this, stated with the estimate: 25%; middle value at least 5.0-fold (0.69 log units) from the limit.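

Within the data shown here, compound 3 and compound 4 each return only a limit and not a number in this assay, so no step between them can be read. The compounds shown leave open whether pyridin-2-yl in place of cyclopropyl on a sulfonyl sulfur changes the clearance at all on this shared core.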